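From methoxy to hydroxy: compound 2 and compound 3

The source may hold more compounds than are shown below. What is called first, only, known or untested is meant among the compounds shown, and "the series" means these compounds.

In a functional assay on HepG2 cells (Homo sapiens) for antiproliferative activity, read by MTT assay, with a stated time of 24 h (a higher number here means a weaker inhibitor, a lower number a stronger inhibitor), compound 2 `C=CCc1cc(-c2cccc([N+](=O)[O-])c2)ccc1OC` gives > 100000 nM, which is a limit of the assay and not a number. Compound 3 `C=CCc1cc(-c2cccc([N+](=O)[O-])c2)ccc1O` differs from it by a single change, hydrogen in place of methyl on an oxygen on an aromatic ring, methoxy to hydroxy. In this assay compound 1 `C=CCc1cc(-c2cccc(C(F)(F)F)c2)ccc1O`, which also carries the hydroxy, gives 58300 nM, so a moderate move towards a stronger inhibitor is expected. The expected change is an at least 1.8-fold lower number from compound 2 to compound 3 (0.25 log units; that floor lies within the scatter). The estimate for compound 3 is 55000 nM, with an expected range from 22000 nM to 110000 nM.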

Compound 3, half-maximal inhibitory concentration: > 100000 nM
Compound 3 ended at the assay's limit (the forecaster's own chance of this, stated with the estimate: 25%); at least 1.8-fold (0.25 log units) between middle value and limit.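

In this assay the step from methoxy to hydroxy cannot be read, since both ends are limits of the assay: the limit of > 100000 nM in this assay, at which 2 of the 3 values shown sit.

With nitro on the ring, the hydroxy of compound 3 still leaves only a limit, so compound 1 alone gives a real number. Nitro in place of trifluoromethyl on an aromatic carbon gives an at least 1.7-fold higher number from compound 1 to compound 3 (0.23 log units; that floor lies within the scatter), and this floor alone does not separate the two groups.

From the compounds shown here alone, whether methoxy to hydroxy changes activity at all stays open. So does how an amine or a carboxylic acid in place of the nitro would read.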